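Aryl swap from compound 1 to compound 4

The source may hold more compounds than are shown below. What is called first, only, known or untested is meant among the compounds shown, and "the series" means these compounds.

Of the compounds shown here, three have been read so far in a functional assay on Hs-578T cells (Homo sapiens) for inhibition, read by sulforhodamine B assay, with a stated time of 48 h; on this read-out higher numbers stand for weaker inhibition of growth and lower numbers for stronger inhibition of growth. Compound 1 (`O=C(Nc1cccc(-n2cc(-c3ccncc3)c(-c3ccc(Cl)c(O)c3)n2)c1)Nc1cccc(C(F)(F)F)c1`) gives > 32500 nM, which is a limit of the assay and not a number. Compound 3 (`COc1cc(-c2nn(-c3cccc(NC(=O)c4cccc(C(F)(F)F)c4)c3)cc2-c2ccncc2)ccc1Cl`) gives > 50000 nM, again a limit and not a number. Compound 2 (`COc1cc(-c2nn(-c3cccc(NC(=O)Nc4cc(C(F)(F)F)cc(C(F)(F)F)c4)c3)cc2-c2ccncc2)ccc1Cl`) alone gives a true number, at 3680 nM. On these data alone, compound 1 therefore stands at a limit, and its real position on the scale remains open.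

Compound 4 (`O=C(Nc1cccc(-n2cc(-c3ccncc3)c(-c3ccc(Cl)c(O)c3)n2)c1)Nc1ccc(Cl)c(Cl)c1`) keeps the core of compound 1 and changes in one place: 3,4-dichlorophenyl in place of 3-(trifluoromethyl)phenyl on an amide-type nitrogen. Here 3,4-dichlorophenyl stands in place of 3-(trifluoromethyl)phenyl on an amide-type nitrogen.

Within the data shown here, no two measured compounds differ in one place only, so the size of this change in this assay has not been measured. The estimate starts from compound 1, whose > 32500 nM is a limit. A small shift towards stronger inhibition of growth is expected, or none beyond the scatter, and the estimated change is an at least 1.3-fold lower number from compound 1 to compound 4 (0.11 log units; that floor lies within the scatter). A reading that returns only a limit would also fit this expectation. The estimated value for compound 4 is 25000 nM, with an expected range of 8000 nM to 60000 nM.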

Compound 4, concentration for total growth inhibition: 3150 nM
For compound 4 the middle estimate is 7.9-fold (0.90 log units) above the measured one, and the stated range ends above it.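

In this assay, among these compounds, this is the first place where a single change can be read: 3,4-dichlorophenyl in place of 3-(trifluoromethyl)phenyl on an amide-type nitrogen gives an at least 10-fold lower number from compound 1 to compound 4 (1.01 log units; beyond the scatter). With the core of compound 1 held fixed, this aryl group alone is enough to give a true number, with compound 4 at 3150 nM, so growth inhibition responds strongly to what sits at this position. Compound 1 stands at a limit and not a number, so the size of the step is only a floor: the limit of > 32500 nM in this assay, at which 1 of the 4 values shown sits.

The compounds shown do not separate the contribution of the two chlorines from that of losing the trifluoromethyl group, and it remains open whether a phenyl ring with a single chlorine, a methoxy group or a nitrile would hold the same level of growth inhibition. On these data alone, it is also open whether the same swap would carry over to the methoxy-bearing core of compound 2, which differs from compound 4 in more than one place and so gives no direct comparison.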